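The compounds below may be only part of what the source reports. "The series", "measured", "known", "first", "only" and "open" are said of these compounds alone.

Measured in a functional assay on SiHa cells (Homo sapiens) for inhibition, read by sulforhodamine B assay; a higher number here means a weaker inhibitor of growth, a lower number a stronger inhibitor of growth:
- compound 1 `Cc1ccc2[nH]c(-c3ccc(-c4ccc(-c5ccc(N(C)C)cc5)cc4)cc3)nc2c1`: 7110 nM
- compound 2 `COc1cc(-c2ccc(-c3ccc(-c4nc5cc(C)ccc5[nH]4)cc3)cc2)cc(OC)c1OC`: 170 nM
- compound 3 `FC(F)(F)c1ccc(-c2ccc(-c3ccc(-c4nc5ccccc5[nH]4)cc3)cc2)cc1`: 100000 nM

Compound 3 has the highest number of the three, and its distance from both compound 1 and compound 2 lies beyond the scatter. This makes it the weakest inhibitor of growth so far in this assay.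

Compound 4 `COc1ccc(-c2ccc(-c3ccc(-c4nc5ccccc5[nH]4)cc3)cc2)cc1` has methoxy in place of trifluoromethyl on an aromatic carbon, para to a large group: methoxy in place of trifluoromethyl on an aromatic carbon. Among the compounds with values here, no measured pair differs in only one place, so the expectation rests on values alone and is loose. Compound 2 also carries methoxy and gives 170 nM. Compound 1 has no methoxy and gives 7110 nM. Both also differ from compound 4 elsewhere, so neither is a direct guide.

A large drop in the number, beyond the scatter, is expected, with the estimated size being a 33-fold lower number from compound 3 to compound 4 (1.52 log units; beyond the scatter). For compound 4 the estimated value is 3000 nM, with an expected range of 400 nM to 25000 nM.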

Compound 4, concentration for 50% growth inhibition: 2760 nM
Estimate against measurement, compound 4: 1.1-fold (0.04 log units) above; the measured number falls inside the stated range.
By their numbers in this assay, from the lowest: compound 2; then compound 4; then compound 1; then compound 3.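

In this assay, within the data shown here, replacing trifluoromethyl with methoxy on an aromatic carbon, para to a large group, gives a 36-fold lower number from compound 3 to compound 4 (1.56 log units; beyond the scatter), the only step here between compounds that differ in one place. Among these compounds, this position is therefore sensitive to the group it carries, which the earlier compounds could not show. The change swaps a group of 4 heavy atoms and no hydrogen-bond acceptor for one of 2 heavy atoms and 1 hydrogen-bond acceptor, but no measurement here links the step to any of these differences or gives a cause for it.

A single pair cannot show whether the step reflects methoxy in particular or whether other groups at this place would do the same. A hydroxyl, a dimethylamino group or a longer alkoxy chain on this otherwise unchanged core would remain to be compared.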